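From hydroxy to methoxy on a weakly cytotoxic compound

This account rests on a few compounds, and the source may have more. Where it says the series, first, only, none or still open, it means among the compounds named here.

Measured in a functional assay on A549 cells (Homo sapiens) for cytotoxicity, read by resazurin assay, with a stated time of 72 h; on this read-out higher numbers stand for weaker inhibition and lower numbers for stronger inhibition:
- compound 1 `COc1cc(/C=C/C(=O)OCCCCCCO[N+](=O)[O-])ccc1O`: 37400 nM
- compound 2 `O=C(/C=C/c1ccc(OCCCCCCO[N+](=O)[O-])c(O)c1)OCCCCCCO[N+](=O)[O-]`: > 50000 nM (a limit, not a number)

Compound 2 sits at the limit of > 50000 nM in this assay, at which 1 of the 2 values shown sits. Compound 3 `COc1cc(/C=C/C(=O)OCCCCCCO[N+](=O)[O-])ccc1OCCCCCCO[N+](=O)[O-]` differs from compound 2 in one place, with methyl in place of hydrogen on an oxygen on an aromatic ring, turning hydroxy to methoxy: methyl in place of hydrogen on an oxygen on an aromatic ring. For the measured compounds named here, no measured pair shows this change on its own, so its size can only be estimated. Compound 3 shares that methoxy with compound 1, which gives 37400 nM, so weak activity is expected again. In this assay no shift beyond the scatter is expected, and the estimate is a number no higher from compound 2 to compound 3 (the limit leaves the size open). For compound 3 the estimated value is 50000 nM, with an expected range from 25000 nM to 100000 nM.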

Compound 3, half-maximal inhibitory concentration: > 50000 nM
Compound 3 was reported as a limit (the forecaster's own chance of this, stated with the estimate: 55%); the middle value lies on the limit itself.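

In this assay, compound 3 is reported only as a limit, > 50000 nM. The change from hydroxy to methoxy therefore has no readable size, because compound 2 and compound 3 both stop at the limit of the assay: the limit of > 50000 nM in this assay, at which 2 of the 3 values shown sit. Putting 6-(nitrooxy)hexyl onto the free hydroxy gives an at least 1.3-fold higher number from compound 1 to compound 3 (0.12 log units; that floor lies within the scatter), so this change brought no stronger inhibition, and the printed floor does not establish a real loss.

As far as these compounds go, how far compound 2 and compound 3 lie past the limit remains open, and so does whether the hydroxy to methoxy change has any effect at all. Also open, from the compounds shown here alone, is what a different group on that oxygen, such as an amine or a carboxylic acid, would do to the cytotoxicity.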